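Swapping a Small Chain for a Nitrile-Bearing Aryl Group

The source may report more compounds than this note shows. Statements on the series, on what has been measured and on what is new or still open speak of the compounds shown alone.

Measured so far:
- compound 1, `CCn1c(=O)n(C2OC(CO)[C@@H](O)[C@H]2O)c2nc(N)nc(O)c21`: 15 uM
- compound 2, `C=CCn1c(=O)n([C@@H]2O[C@H](CO)[C@H]3OC(CCC)(CCC)O[C@H]32)c2nc(N)nc(O)c21`: 4 uM

In a functional assay (B cells) with Mus musculus as the target (a lower number here means that less compound is needed, a higher number that more compound is needed for the effect), compound 1 gives 15 uM, the higher of the two numbers here; compound 2 gives the lower number, and the gap lies beyond the usual scatter. Compound 3, `N#Cc1ccc(Cn2c(=O)n(C3OC(CO)[C@@H](O)[C@H]3O)c3nc(N)nc(O)c32)cc1`, has not been measured. It differs from compound 1 in one place: 4-cyanophenyl in place of methyl on a saturated chain carbon bound to an aromatic nitrogen. Going by the values given here, no measured pair shows this change, so the expectation rests on the change alone. The step of a 1.9-fold lower number from compound 1 to compound 3 (0.27 log units; within the scatter) is expected to be a modest move toward a lower number, possibly within scatter. Compound 3 is estimated at 8 uM, with a range from 2 uM to 40 uM.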

Compound 3, concentration for half-maximal effect: 15 uM
Estimate against measurement, compound 3: 1.9-fold (0.27 log units) below; the measured number falls inside the stated range.
By their numbers in this assay, from the lowest: compound 2; then compounds 1 and 3 (each within the scatter of the next).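

In this assay, exchanging ethyl for 4-cyanobenzyl gives no change at the digits printed from compound 1 to compound 3 (within the scatter) even though the change adds a six-membered aromatic ring and a nitrile. This position, a saturated chain carbon bound to an aromatic nitrogen, therefore carries this much larger group with no readable effect on the number. Nothing measured here offers a reason for this.

Going by these compounds, it remains open whether a plain benzyl group without the nitrile would give the same result. A carboxylic acid or an amine on that ring might also behave differently.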